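This account rests on a few compounds, and the source may have more. Where it says the series, first, only, none or still open, it means among the compounds named here.

Values in a functional assay on HL-60 cells (Homo sapiens) for inhibition, read by MTT assay, with a stated time of 48 h, tested at 10 uM; a higher number here means more inhibition of growth at the concentration tested, a lower number less inhibition of growth:
- compound 1 `CCN(CC)Cc1c(O)c([C@H]2CCN(C)C[C@H]2O)c2oc(C)cc(=O)c2c1O`: 47%
- compound 2 `Cc1cc(=O)c2c(O)c(CN(C)CC(=O)O)c(O)c([C@H]3CCN(C)C[C@H]3O)c2o1`: 23%
- compound 3 `Cc1oc2c([C@H]3CCN(C)C[C@H]3O)c(O)cc(O)c2c(=O)c1C(O)c1c(F)cccc1Cl`: 49%

In this series, compound 3 at 49% sits level with compound 1 at 47% within the scatter, while compound 2 at 23% lies lower, beyond the scatter.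

The next compound is compound 4 `Cc1oc2c([C@H]3CCN(C)C[C@H]3O)c(O)cc(O)c2c(=O)c1C(O)c1cccc(Cl)c1Cl`, which differs from compound 3 as follows: 2,3-dichlorophenyl in place of 2-chloro-6-fluorophenyl on a saturated chain carbon bound to an aromatic carbon and an oxygen on a saturated carbon. In words, 2,3-dichlorophenyl stands in place of 2-chloro-6-fluorophenyl on a saturated chain carbon bound to an aromatic carbon and an oxygen on a saturated carbon.

Among the measured compounds shown here, the only measured step is modest: a number 24 percentage points lower from compound 1 to compound 2 (beyond the scatter). It concerns a different change at a different place, so it bears on this swap only weakly. For the measured compounds named here, no measured pair varies the aryl group, and the data give no direction. The expected step, a number 1 percentage points lower from compound 3 to compound 4 (within the scatter), is therefore none beyond the scatter. Compound 4 is estimated at 48%, with an expected range of 32% to 64%.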

Compound 4, percent growth inhibition at one concentration: 12%
The estimate for compound 4 lay 36 percentage points above the measured number; the whole stated range lies above it.
By their numbers in this assay, from the lowest: compound 4; then compound 2; then compounds 1 and 3 (each within the scatter of the next).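

Among the compounds shown here, on the saturated chain carbon bound to an aromatic carbon and an oxygen, the aryl group has a large effect in this assay: 2,3-dichlorophenyl in place of 2-chloro-6-fluorophenyl gives a number 37 percentage points lower from compound 3 to compound 4 (beyond the scatter) and this is the first measured step at this position, since the only earlier step concerned the amino group. The two groups match in what is counted here (8 heavy atoms, one six-membered aromatic ring of carbon only, no hydrogen-bond donors or acceptors, no net charge), so these counts do not separate them, yet the read-out still falls sharply. No measurement available here accounts for this drop.

The swap changes both the halogen set and the substitution pattern, so the two cannot be told apart. Plain phenyl and 2,6-dichlorophenyl on the same carbon would be the groups that separate them.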